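Trading One Hydroxy for Hydrogen in a Potent Growth Inhibitor

This account rests on a few compounds, and the source may have more. Where it says the series, first, only, none or still open, it means among the compounds named here.

Three compounds have entries in a functional assay on SK-OV-3 cells (Homo sapiens) for inhibition, read by sulforhodamine B assay, with a stated time of 48 h (a lower number here means a stronger inhibitor of growth, a higher number a weaker inhibitor of growth), but only two of them carry a reading. For compound 1 `COc1ccc(C(=O)C2=CCCCc3c2cc(OC)c(OC)c3OC)c(O)c1O`, the entry is "not determined" (no result reported), so it offers no guidance here. Compound 3 `COc1ccc(C(=O)C2=CCCc3c2cc(OC)c(OC)c3OC)c(O)c1O` gives 1400 nM, a measured number.

Compound 2 `COc1ccc2c(c1O)CCCC=C2c1cc(OC)c(OC)c(OC)c1` reads < 0.03 nM, which is a limit of the assay and not a number. On the numbers shown, compound 2 therefore stands at the limit of < 0.03 nM in this assay, at which 1 of the 3 values shown sits.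

Compound 4 `COc1ccc2c(c1)CCCC=C2c1cc(OC)c(OC)c(OC)c1` has not yet been measured. It differs from compound 2 in a single place, with hydrogen in place of hydroxy on an aromatic carbon, ortho to a methoxy group (hydrogen in place of hydroxy on an aromatic carbon). The rest of the structure is unchanged.

Within the data shown here, no pair of measured compounds shows this change on its own, so any forecast remains a judgement resting on the structural change alone. In this assay, a weakening well beyond the usual scatter is expected when the hydroxy leaves, although potent growth inhibition should probably survive. The expected size of the change is an at least 160-fold higher number from compound 2 to compound 4 (2.22 log units; beyond the scatter), and it remains an estimate with wide uncertainty. For compound 4, the estimated value is 5 nM, with an expected range from 0.3 nM to 60 nM.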

Compound 4, concentration for 50% growth inhibition: 52 nM
Compound 4: middle estimate off by 10-fold (1.02 log units), on the low side; low and high end bracket the measured number.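

This step gives the first measured weight for the hydroxy ortho to a methoxy group. Among these compounds, no earlier pair isolated this place. In this assay, the change to hydrogen gives an at least 1700-fold higher number from compound 2 to compound 4 (3.23 log units; beyond the scatter), so a single oxygen atom on the aromatic ring separates the two compounds by a large margin. Compound 4 still reads 52 nM, which shows that growth inhibition survives the loss of the hydroxy. The full size of the loss remains unknown, since the reading for compound 2 is a limit of the assay and not a number: the limit of < 0.03 nM in this assay, at which 1 of the 4 values shown sits.

The compounds shown carry only hydroxy or hydrogen at this place, so they leave open how an amine or a fluorine atom there would read, and with it whether the oxygen or the hydrogen-bond donor count matters more. They also leave open whether a step of this size would appear on the core of compound 3, whose ring differs from that of compound 2 and which also carries a carbonyl.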